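The source may hold more compounds than are shown below. What is called first, only, known or untested is meant among the compounds shown, and "the series" means these compounds.

Compound 1 `COC(=O)C1=C(CN2CCOCC2=O)NC(c2nccs2)=NC1(C)c1ccc(F)cc1`: 80 mL/min/kg
Compound 2 `COC(=O)C1=C(CN2CCC[C@@H]2C(=O)O)NC(c2nccs2)=N[C@@]1(C)c1ccc(F)cc1`: 60 mL/min/kg

These values come from an ADME assay on microsomes from liver (Mus musculus) for metabolic stability, read by LC-MS, using NADPH, with stated times of 10 min and 30 min, tested at 1 uM; on this read-out higher numbers stand for fast clearance and lower numbers for slow clearance. Compound 2 has the lower number, but its gap to compound 1 lies within the usual scatter, so the two cannot be told apart. Compound 3 `COC(=O)C1=C(CN2CCC[C@H]2C(=O)O)NC(c2nccs2)=N[C@@]1(C)c1ccc(F)cc1` differs from compound 2 in one way: the two compounds have the same atoms and bonds and differ only in configuration as drawn: 1 of 2 stereo elements differ; a stereocentre at a saturated ring carbon is drawn R in compound 2 and S in compound 3. The two compounds have the same atoms and bonds, and a stereocentre at a saturated ring carbon is drawn R in compound 2 and S in compound 3. Among the compounds with values here, no measured pair shows what such a change does, so no shift beyond the scatter is expected in this assay, in either direction. The expected step is no change at the digits printed from compound 2 to compound 3 (within the scatter). The estimate for compound 3 is 60 mL/min/kg, within a range of 30 mL/min/kg to 110 mL/min/kg.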

Compound 3, clearance in the Mus musculus assay: 14 mL/min/kg
The estimate for compound 3 lay 4.3-fold (0.63 log units) above the measured number, and the stated range ends above it.
By their numbers in the Mus musculus assay, from the lowest: compound 3; then compounds 2 and 1 (each within the scatter of the next).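

Configuration at this saturated ring carbon matters on its own: in the Mus musculus assay there is a 4.3-fold lower number from compound 2 to compound 3 (0.63 log units; beyond the scatter), with compound 2 at 60 mL/min/kg and compound 3 at 14 mL/min/kg, and no earlier pair showed what such a change does. Since nothing else changes, this step can be tied to the drawn configuration alone: the fact that compounds 2 and 3 differ only in the configuration as drawn In a physicochemical assay for solubility, read by HPLC, in phosphate buffer, at pH 6.5 (on this read-out lower numbers stand for lower solubility and higher numbers for higher solubility), compound 2 gives > 659 ug/mL, which is a limit of the assay. In the physicochemical assay compound 3 gives > 589 ug/mL, which is also a limit of the assay. The step between these two compounds in the physicochemical assay cannot be read.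

The compounds shown leave open whether the S configuration would give a lower clearance number if a primary amide took the place of the carboxylic acid.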